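Acetamidophenyl Swap on a Weakly Active Spiro Series

This account rests on a few compounds, and the source may have more. Where it says the series, first, only, none or still open, it means among the compounds named here.

Going by the values given here, compound 3 `N#CC1=C(N)Oc2c(N)cc3nc4ccccc4nc3c2C12C(=O)N(Cc1cnnn1-c1ccccc1Br)c1ccccc12` is the one member of this small set that returns a number in a functional assay on HepG2 cells (Homo sapiens) for antiproliferative activity, read by MTT assay, with a stated time of 48 h (on this read-out higher numbers stand for weaker inhibition and lower numbers for stronger inhibition), where compound 3 gives 38000 nM. Compound 1 `Cc1ccccc1-n1nncc1CN1C(=O)C2(C(C#N)=C(N)Oc3c(N)cc4nc5ccccc5nc4c32)c2ccccc21` reaches only a limit of the assay, > 50000 nM. Compound 2 `N#CC1=C(N)Oc2c(N)cc3nc4ccccc4nc3c2C12C(=O)N(Cc1cnnn1-c1cccc(Br)c1)c1ccccc12` likewise reaches only a limit, > 50000 nM. Two of the three results therefore sit at the limit of > 50000 nM in this assay, at which 2 of the 3 values shown sit, which leaves the step that the two limits leave unreadable from compound 1 to compound 2 unreadable. The steps of an at least 1.3-fold lower number from compound 1 to compound 3 (0.11 log units; that floor lies within the scatter) and an at least 1.3-fold lower number from compound 2 to compound 3 (0.11 log units; that floor lies within the scatter) are each only a floor that lies within the usual scatter, so compound 3 cannot be called more potent than the other two.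

Compound 4 `CC(=O)Nc1ccc(-n2nncc2CN2C(=O)C3(C(C#N)=C(N)Oc4c(N)cc5nc6ccccc6nc5c43)c3ccccc32)cc1` differs from compound 3 in one place: 4-acetamidophenyl in place of 2-bromophenyl on an aromatic nitrogen. None of the measured steps exchanges the group on the aromatic nitrogen for one carrying a hydrogen-bond donor or acceptor, so no shown step bears directly on this change, and the two readable floors around compound 3 were small and within scatter. The expectation is therefore no step beyond the scatter, with a real chance that compound 4 again returns only a limit. The step expected from compound 3 to compound 4 is a 1.2-fold higher number from compound 3 to compound 4 (0.07 log units; within the scatter). Compound 4 is expected to give about 45000 nM, within a range from 15000 nM to 150000 nM.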

Compound 4, half-maximal inhibitory concentration: > 50000 nM
Compound 4 gave a limit, no number (the forecaster's own chance of this, stated with the estimate: 55%); at least 1.1-fold (0.04 log units) between middle value and limit.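

Compound 4 is the only compound shown whose group on the aromatic nitrogen carries a hydrogen-bond donor and a hydrogen-bond acceptor, and in this assay this 4-acetamidophenyl group brought no readable gain in inhibition over the 2-bromophenyl group. The exchange gives an at least 1.3-fold higher number from compound 3 to compound 4 (0.11 log units; that floor lies within the scatter) and so supports no claim of a real difference in potency, though it does show that adding these features at this position did not bring a number clear of the scatter. The steps from compound 1 and from compound 2 to compound 4 cannot be read, and the series remains concentrated at a single limit: the limit of > 50000 nM in this assay, at which 3 of the 4 values shown sit.

From the compounds shown here alone, whether a carboxylic acid or an amine on the phenyl ring, or a longer chain in its place, would give a number beyond the scatter from compound 3 stays open. Also open, going by these compounds, is whether the acetamide group or its place on the phenyl ring matters more, as the step from 2-bromophenyl to 4-acetamidophenyl changes both at once.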